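The source may hold more compounds than are shown below. What is called first, only, known or untested is meant among the compounds shown, and "the series" means these compounds.

Series notes. Compound 1 `C=C1CC[C@@H]2[C@](C)(CO[C@@H]3O[C@H](CO)[C@@H](O)[C@H](O)[C@H]3O)CCC[C@@]2(C)[C@@H]1CCC1=CCOC1=O` and compound 2 `C=C1CC[C@@H]2[C@](C)(CO)CCC[C@@]2(C)[C@@H]1CCC1=CCOC1=O` share one core and differ at a single place. In a functional assay on HL-60 cells (Homo sapiens) for antiproliferative activity, read by trypan blue exclusion (a lower number here means a stronger inhibitor of growth, a higher number a weaker inhibitor of growth), compound 1 gives 26700 nM, and in this assay compound 2 gives 20000 nM. For the measured compounds named here, the only measured step, a 1.3-fold lower number from compound 1 to compound 2 (0.13 log units; within the scatter), put hydrogen in place of 3,4,5-trihydroxy-6-(hydroxymethyl)oxan-2-yl on an oxygen on a saturated carbon. On these two numbers compound 2 stands lowest, its nearest neighbour being compound 1, within the scatter of it.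

Compound 3 `C=C1CC[C@@H]2[C@](C)(CO)CCC[C@@]2(C)[C@@H]1CC/C(=C/CO)CO` follows from compound 2 by a change at another place: a group of 6 heavy atoms (4 carbon, 2 oxygen; no ring) in place of a group of 6 heavy atoms (4 carbon, 2 oxygen; one five-membered non-aromatic ring with 1 hetero atom), on a saturated chain carbon, two bonds along the chain from a saturated ring carbon. Going by the values given here, no measured step touches this part of the molecule; the step between compound 1 and compound 2 lies elsewhere and is within the scatter, so it gives no scale for this change. The expectation for compound 3 therefore rests on compound 2 alone, with a wide range. Compound 3 is expected to show a step of a 1.8-fold higher number from compound 2 to compound 3 (0.24 log units; within the scatter), with no direction claimed beyond the scatter. Compound 3 is estimated at 35000 nM in this assay, with a range from 10000 nM to 150000 nM.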

Compound 3, concentration for 50% growth inhibition: 20400 nM
Beside the measured number, compound 3's estimate is 1.7-fold (0.23 log units) above it; low and high end bracket the measured number.
By their numbers in this assay, from the lowest: compounds 2, 3 and 1 (each within the scatter of the next).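

In this assay, for the compounds shown here, 3-hydroxy-1-(hydroxymethyl)prop-1-en-1-yl in place of the group with the five-membered non-aromatic ring gives a 1.0-fold higher number from compound 2 to compound 3 (0.01 log units; within the scatter), the first measured change at this place on the chain. For this pair, then, losing the ring and going from 0 to 2 hydrogen-bond donors leaves the number within the scatter, so the closed ring is not needed to hold growth inhibition at this level. Nothing available explains this result.

Going by these compounds, neither measured step among the three compounds lies beyond the scatter, so what at either place would move the number remains open. Whether an amine or a carboxylic acid at the end of this chain, or a longer chain, would give a clear step is also unanswered.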